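Adding a second chloro to the phenyl of compound 1

This account rests on a few compounds, and the source may have more. Where it says the series, first, only, none or still open, it means among the compounds named here.

Compound 1 `Cc1nc(-c2ccc(F)cc2)c(C(=O)N2CCN(c3cccc(Cl)c3)CC2)o1` is the stronger of the two compounds measured in a functional assay on HL-60 cells (Homo sapiens) for inhibition, read by MTT assay, with a stated time of 72 h (a higher number here means a weaker inhibitor, a lower number a stronger inhibitor), where compound 1 gives 40.1 nM. Compound 2 `CC(=O)Nc1cccc(-c2nc(C)oc2C(=O)N2CCN(c3cccc(Cl)c3)CC2)c1` carries a 3-acetamidophenyl in place of the 4-fluorophenyl, and in this assay compound 2 gives 208 nM, a step of a 5.2-fold higher number from compound 1 to compound 2 (0.71 log units; beyond the scatter). Compound 3 `Cc1nc(-c2ccc(F)cc2)c(C(=O)N2CCN(c3cc(Cl)cc(Cl)c3)CC2)o1` differs from compound 1 at the other end of the shared core: chloro in place of hydrogen on an aromatic carbon, so that the 3-chlorophenyl becomes a 3,5-dichlorophenyl. For the measured compounds named here, the only measured step touches the aryl group on the oxazole side, not the ring bearing the chloro, so no measured step bears directly on this change. With nothing to guide it in either direction, the number for compound 3 is expected to stay close to that of compound 1, a step of a 1.1-fold higher number from compound 1 to compound 3 (0.05 log units; within the scatter) that lies within the scatter. The estimate for compound 3 in this assay is 45 nM, between 15 nM and 135 nM.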

Compound 3, half-maximal inhibitory concentration: 52.1 nM
For compound 3 the middle estimate is 1.2-fold (0.06 log units) below the measured one; low and high end bracket the measured number.
By their numbers in this assay, from the lowest: compounds 1 and 3 (each within the scatter of the next); then compound 2.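

In this assay the step to the 3,5-dichlorophenyl is a 1.3-fold higher number from compound 1 to compound 3 (0.11 log units; within the scatter), so the added chloro leaves the number where it was. For the compounds shown here, this is the first measured change on the ring bearing the chloro, and it shows that this place, meta to a chloro group, takes one more chlorine with no shift beyond the scatter, unlike the earlier step on the aryl group at the other end of the shared core. Nothing measured here explains why the added chloro makes so little difference.

The compounds shown leave open whether a methoxy, an amine or a carboxylic acid at this place would also stay within the scatter or would move the number. They also leave open whether the 3,5-dichlorophenyl would give an equally small step alongside the 3-acetamidophenyl of compound 2.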